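Aryl exchange on the sulfonamide of compound 1

The source may hold more compounds than are shown below. What is called first, only, known or untested is meant among the compounds shown, and "the series" means these compounds.

Compound 1 `Cc1ccc(S(=O)(=O)Nc2cc(N)cc(-c3cnc4[nH]cc(-c5ccncc5)c4c3)c2)cc1`: 4.62 nM in an assay on isolated protein for inhibition of high affinity nerve growth factor receptor (Homo sapiens), read by 33P incorporation; on this read-out lower numbers stand for stronger inhibition and higher numbers for weaker inhibition
Compound 2 `Nc1cccc(-c2cnc3[nH]cc(-c4ccncc4)c3c2)c1`: 42.7 nM in this assay
Compound 3 `Nc1ccc(-c2cnc3[nH]cc(-c4ccncc4)c3c2)cc1`: 25 nM in this assay

Compound 1 gives the lowest of the three numbers in this assay; compound 3 lies nearest to it and compound 2 furthest, both beyond the scatter. Compound 4 `Nc1cc(NS(=O)(=O)c2ccc(F)cc2F)cc(-c2cnc3[nH]cc(-c4ccncc4)c3c2)c1` differs from compound 1 by 2,4-difluorophenyl in place of 4-methylphenyl on a sulfonyl sulfur. Within the data shown here, no measured step alters the aryl on the sulfonyl sulfur; the step that bears most on it is the loss of the whole sulfonamide, a 9.2-fold higher number from compound 1 to compound 2 (0.97 log units; beyond the scatter), which shows that this group matters. The step of a 1.7-fold lower number from compound 2 to compound 3 (0.23 log units; within the scatter) concerns only the amine and not this change. Compound 4 is therefore expected to stay close to compound 1, with a step of a 1.1-fold higher number from compound 1 to compound 4 (0.03 log units; within the scatter) within the scatter, and an estimated value of 5 nM (range 1.8 nM to 15 nM).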

Compound 4, half-maximal inhibitory concentration: 2.97 nM
Compound 4: the middle estimate sits 1.7-fold (0.23 log units) above what was measured; measured number inside the range.
By their numbers in this assay, from the lowest: compounds 4 and 1 (each within the scatter of the next); then compounds 3 and 2 (each within the scatter of the next).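

In this assay, 2,4-difluorophenyl in place of 4-methylphenyl on the sulfonyl sulfur gives a 1.6-fold lower number from compound 1 to compound 4 (0.19 log units; within the scatter) and so leaves the reading within the scatter. The earlier compounds shown here showed only that losing the whole sulfonamide counts, whereas this pair shows that the aryl on the sulfonyl sulfur can be exchanged without a step beyond the scatter. Nothing at hand explains why these two aryl groups read alike. Open, going by these compounds, is how the number responds to a methyl group or a pyridine ring on the sulfonyl sulfur, and what each fluorine contributes alone.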